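Moving a methyl around the benzyl ring of a uracil anilide

This account rests on a few compounds, and the source may have more. Where it says the series, first, only, none or still open, it means among the compounds named here.

Two compounds of this series carry a benzyl group on the shared core. Compound 1 `O=c1[nH]c(=O)n(Cc2ccccc2)cc1Nc1ccccc1` has an unsubstituted benzyl group, and in an ADME assay on Akata cells (Homo sapiens) for cytotoxicity, read by XTT assay (on this read-out lower numbers stand for higher toxicity in this test and higher numbers for lower toxicity in this test), compound 1 gives "not determined" (no result reported). Compound 2 `Cc1ccccc1Cn1cc(Nc2ccccc2)c(=O)[nH]c1=O` adds a methyl to that ring. In this assay compound 2 gives > 100000 nM, which is a limit of the test rather than a number. This places compound 2 at the limit of > 100000 nM in this assay, at which 1 of the 2 values shown sits, so it shows no measurable toxicity within the tested range.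

Compound 3 `Cc1cccc(Cn2cc(Nc3ccccc3)c(=O)[nH]c2=O)c1` is the same set of atoms joined differently: 3-methylphenyl in place of 2-methylphenyl on a saturated chain carbon bound to an aromatic nitrogen. Within the data shown here, no measured step of this kind exists here, so the expectation rests on compound 2 alone. The step of a number no higher from compound 2 to compound 3 (the limit leaves the size open) is expected to be none beyond the scatter. Compound 3 is therefore expected to give about 100000 nM, within 30000 nM to 300000 nM, most likely again reported only as a limit.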

Compound 3, half-maximal cytotoxic concentration: > 100000 nM
Compound 3: only a limit was reported; the forecaster's own chance of this, stated with the estimate: 80%; the middle value lies on the limit itself.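

In this assay, among these compounds, compound 2 and compound 3 are both reported only as limits, so no step between them can be read: the limit of > 100000 nM in this assay, at which 2 of the 3 values shown sit.

From the compounds shown here alone, what stays open is where the true toxicity of compound 2 and compound 3 lies, and whether the methyl's place on the benzyl ring matters at all.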